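The source may hold more compounds than are shown below. What is called first, only, known or untested is meant among the compounds shown, and "the series" means these compounds.

Measured compounds in a functional assay on P388 cells (Mus musculus) for antiproliferative activity, with a stated time of 72 h; a lower number here means a stronger inhibitor, a higher number a weaker inhibitor:
compound 1, `CSc1cnc2ccccc2c1[Se]CC#CCO`, 2.6 ug/mL
compound 2, `CSc1cnc2ccccc2c1[Se]CC#CCCl`, 0.4 ug/mL
compound 3, `C#CCSc1cnc2ccccc2c1SCC#CCCl`, 3 ug/mL

Compound 3 has the highest number of the three. Its value and that of compound 1 lie within the scatter of each other; compound 2 sits at a lower number, beyond the scatter. Within the data shown here, the only measured step, a 6.5-fold lower number from compound 1 to compound 2 (0.81 log units; beyond the scatter), concerns chloro in place of hydroxy on a saturated chain carbon bound to a triple-bonded carbon, not the group on the saturated chain carbon bound to a sulfur. Compound 4, `CSc1cnc2ccccc2c1SCC#CCCl`, differs from compound 3 by hydrogen in place of ethynyl on a saturated chain carbon bound to a sulfur, propargylsulfanyl to methylsulfanyl. Among the measured compounds shown here, no measured step bears on this change, so no step beyond the scatter is expected in this assay in either direction. Compound 4 is therefore estimated at 2.2 ug/mL, range 0.7 ug/mL to 6 ug/mL. The expected step is a 1.4-fold lower number from compound 3 to compound 4 (0.13 log units; within the scatter).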

Compound 4, concentration for 50% inhibition: 2.7 ug/mL
For compound 4 the middle estimate is 1.2-fold (0.09 log units) below the measured one, and the stated range covers the measured number.
By their numbers in this assay, from the lowest: compound 2; then compounds 1, 4 and 3 (each within the scatter of the next).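

In this assay, swapping propargylsulfanyl for methylsulfanyl on the chloro-bearing sulfur compound leaves the number unmoved (a 1.1-fold lower number from compound 3 to compound 4 (0.05 log units; within the scatter)), so this position shows no sensitivity to this change. The group on the aromatic carbon does matter: sulfur in place of selenium, with the chloro chain kept, gives a 6.8-fold higher number from compound 2 to compound 4 (0.83 log units; beyond the scatter). The swap that also replaces hydroxy with chloro gives a 1.0-fold higher number from compound 1 to compound 4 (0.02 log units; within the scatter), which joins two changes and cannot separate them.

Open, on these data alone, is whether an amine or a longer chain in place of methylsulfanyl would behave the same, and whether the selenium compounds would also tolerate propargylsulfanyl. No measurement at hand accounts for the selenium-to-sulfur step.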